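Methyl to ethyl on the urea aryl ring

A few compounds are considered here, and "the series" means these few. Any claim that something is new, unique, unknown or untested is made for them only; others in the source may bear on it.

Compound 1 `CNc1cc(Oc2ccc(NC(=O)Nc3cccc(C)c3)cc2)ncn1`: 1260 nM
Compound 2 `CCc1cc(NC(=O)Nc2cccc(C(F)(F)F)c2)cc(Cl)c1Oc1cc(NC)ncn1`: <= 10 nM

In an assay on isolated protein for inhibition of serine/threonine-protein kinase TNNI3K (Homo sapiens) (a higher number here means a weaker inhibitor, a lower number a stronger inhibitor), compound 1 gives 1260 nM, the only plain number shown. Compound 2 sits at <= 10 nM, which is a limit of the assay rather than a number (the limit of <= 10 nM in this assay, at which 1 of the 2 values shown sits). Compound 3 `CCc1cccc(NC(=O)Nc2ccc(Oc3cc(NC)ncn3)cc2)c1` differs from compound 1 by methyl in place of hydrogen on a saturated chain carbon bound to an aromatic carbon. For the measured compounds named here, no measured pair shows this change, so the step from compound 1 to compound 3 is expected to stay within the usual scatter, with no clear direction, a 1.3-fold lower number from compound 1 to compound 3 (0.10 log units; within the scatter). Compound 3 is therefore estimated at 1000 nM, between 350 nM and 3000 nM.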

Compound 3, half-maximal inhibitory concentration: 200 nM
For compound 3 the middle estimate is 5.0-fold (0.70 log units) above the measured one; the whole stated range lies above it.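

In this assay, the added methyl that turns 3-methylphenyl into 3-ethylphenyl gives a 6.3-fold lower number from compound 1 to compound 3 (0.80 log units; beyond the scatter). This is the first single-place step shown at this position, and it lies beyond the scatter, so the read-out responds to this small change on the saturated chain carbon. Nothing shown accounts for the size of this step.

For the compounds shown here, with only this one step, it remains open whether a longer chain such as propyl or a branched group such as isopropyl would extend the change or reverse it.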